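Aryl alkyne cores and the chloro-for-methyl swap

This account rests on a few compounds, and the source may have more. Where it says the series, first, only, none or still open, it means among the compounds named here.

Compound 1 `CNC(=O)c1ccc(C#Cc2ccccc2)nc1`: 15000 nM
Compound 2 `O=C(NC1CCCC1)c1ccc(C#Cc2cccnc2)nc1`: > 32000 nM
Compound 3 `Cc1cccc(C#Cc2ccc3c(n2)CCN(C)C3=O)c1`: 820 nM

In an assay on HEK293 cells for displacement of a labelled ligand from metabotropic glutamate receptor 5 (Homo sapiens), with a stated time of 2 h (on this read-out higher numbers stand for weaker inhibition and lower numbers for stronger inhibition), compound 3 holds the lowest of the two numbers given; compound 1 sits well beyond the scatter above it. For compound 2 only a limit is reported, (the limit of > 32000 nM in this assay, at which 1 of the 3 values shown sits), so its value is not a number. For the measured compounds named here, no pair of measured compounds differs in a single place, so no measured step is available for comparison. Compound 4 `CN1CCc2nc(C#Cc3ccc(Cl)cc3)ccc2C1=O` differs from compound 3 by 4-chlorophenyl in place of 3-methylphenyl on a triple-bonded carbon. Going by the values given here, with no matching step measured, a modest shift toward weaker inhibition is expected for this change, roughly at the edge of the scatter, as a 1.8-fold higher number from compound 3 to compound 4 (0.26 log units; within the scatter). Compound 4 is therefore estimated at 1500 nM, between 400 nM and 6000 nM.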

Compound 4, inhibition constant: 6150 nM
Estimate against measurement, compound 4: 4.1-fold (0.61 log units) below; the whole stated range lies below it.
By their numbers in this assay, from the lowest: compound 3; then compound 4; then compound 1. At a limit, above all of these: compound 2.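

In this assay, for the compounds shown here, replacing 3-methylphenyl with 4-chlorophenyl on the triple-bonded carbon gives a 7.5-fold higher number from compound 3 to compound 4 (0.88 log units; beyond the scatter) and provides the first measured single-place change in this set. The result shows that this position can respond clearly to a swap between groups of equal heavy-atom count. Nothing measured here accounts for the size of this step.

The swap changes both the substituent and its location on the ring, and the compounds shown do not separate these two changes. As far as these compounds go, how a methoxy group on this ring would compare also remains open.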